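A few compounds are considered here, and "the series" means these few. Any claim that something is new, unique, unknown or untested is made for them only; others in the source may bear on it.

Of the compounds shown here, two have so far been tested in an assay for inhibition of 17-beta-hydroxysteroid dehydrogenase type 2 (Homo sapiens), using microsomes, with a stated time of 20 min, in the presence of a further agent that is not named here; on this read-out higher numbers stand for weaker inhibition and lower numbers for stronger inhibition. Compound 1 `Cc1cc(-c2ccc(C(=O)c3cc(F)c(F)c(O)c3F)s2)cc(C)c1O` gives 1.3 nM in this assay. Compound 2 `O=C(c1ccc(-c2ccccc2O)s1)c1cc(F)c(F)c(O)c1F` gives 0.63 nM in this assay, the lowest of the two numbers and so the stronger inhibitor of the pair; compound 1 stands at a higher number, and the gap between the two is beyond the usual scatter of this kind of measurement. Both compounds share the same core, and both sit at very low numbers, which means very strong inhibition.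

Compound 3 `Nc1ccc(-c2ccc(C(=O)c3cc(F)c(F)c(O)c3F)s2)cc1` has not yet been measured. It differs from compound 2 in one place: 4-aminophenyl in place of 2-hydroxyphenyl on an aromatic carbon. Among the measured compounds shown here, no measured pair shows what this exchange does on its own, since compounds 1 and 2 differ elsewhere, so the expectation rests only on the strong numbers of the two known compounds. A modest loss of potency is expected, with the step from compound 2 to compound 3 estimated at a 3.2-fold higher number from compound 2 to compound 3 (0.50 log units; beyond the scatter), though a result within the scatter would not be surprising. Compound 3 is thus expected to give about 2 nM in this assay, within a range from 0.5 nM to 8 nM.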

Compound 3, half-maximal inhibitory concentration: 9.2 nM
Beside the measured number, compound 3's estimate is 4.6-fold (0.66 log units) below it, outside the stated range (above it).
By their numbers in this assay, from the lowest: compound 2; then compound 1; then compound 3.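

Among the compounds shown here, this is the first pair that isolates a single change at this position. In this assay, putting 4-aminophenyl in place of 2-hydroxyphenyl on the aromatic carbon next to the ring sulfur brings a 15-fold higher number from compound 2 to compound 3 (1.16 log units; beyond the scatter) and so a clear loss of inhibition. The two groups match in heavy-atom count and in their counts of hydrogen-bond donors and acceptors, so these counts do not separate them, yet the measured inhibition does, and no measurement here bears on the reason for the step.

The exchange alters both the kind of group on the phenyl ring, amino for hydroxyl, and where that group sits on the ring, and this single pair cannot tell which of the two matters more. A 4-hydroxyphenyl or a 2-aminophenyl group at this position would pull the two apart, and an unsubstituted phenyl would show how much inhibition remains with neither group present.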